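Moving the chlorine on the aryl group of the azetidinone core

The source may hold more compounds than are shown below. What is called first, only, known or untested is meant among the compounds shown, and "the series" means these compounds.

The measured compounds, in a functional assay on MCF7 cells (Homo sapiens) for antiproliferative activity, read by MTT assay, with a stated time of 48 h; a higher number here means a weaker inhibitor, a lower number a stronger inhibitor:
compound 1 `COC(=O)/C(=C/c1ccccc1)CN1C(=O)[C@@H](OC)[C@H]1c1ccc(Cl)cc1` gives 15300 nM
compound 2 `CCOC(=O)/C(=C/c1ccccc1)CN1C(=O)[C@@H](OC)[C@H]1c1ccc(F)cc1` gives 18800 nM
compound 3 `CCOC(=O)/C(=C/c1ccccc1)CN1C(=O)[C@@H](OC)[C@H]1c1ccccc1Br` gives 5790 nM

Compound 1 stands second highest of the three numbers. Compound 2 sits within the scatter of it, so the two cannot be ordered, while compound 3 lies clearly lower than both. Compound 4 `COC(=O)/C(=C/c1ccccc1)CN1C(=O)[C@@H](OC)[C@H]1c1cccc(Cl)c1` differs from compound 1 in one place: 3-chlorophenyl in place of 4-chlorophenyl on a saturated ring carbon. Among the measured compounds shown here, only one measured step touches the same part of the shared core, the change from compound 2 to compound 3, which gave a 3.2-fold lower number from compound 2 to compound 3 (0.51 log units; beyond the scatter). That step swapped both the halogen and its place on the ring, so it speaks to the present change only loosely; it does show that the aryl group on the saturated ring carbon can move the number by a modest amount. For the measured compounds named here, no step in the data keeps the halogen and changes only where it sits. Compound 4 is therefore estimated at 10000 nM, with a range of 4000 nM to 25000 nM, which would mean an expected step of a 1.5-fold lower number from compound 1 to compound 4 (0.18 log units; within the scatter), a shift that may well remain within the scatter.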

Compound 4, half-maximal inhibitory concentration: 25100 nM
Compound 4: the middle estimate sits 2.5-fold (0.40 log units) below what was measured, and the stated range ends below it.
By their numbers in this assay, from the lowest: compound 3; then compounds 1, 2 and 4 (each within the scatter of the next).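

In this assay, moving the chlorine from the 4-chlorophenyl to the 3-chlorophenyl group gave a 1.6-fold higher number from compound 1 to compound 4 (0.21 log units; within the scatter), the first step shown that keeps the halogen and changes only where it sits on the aryl group. The two chlorophenyl compounds therefore cannot be ordered, and the data give no sign that the place of the chlorine on this aryl group on the saturated ring carbon matters in this assay. No measurement offered here accounts for this result.

The compounds shown leave open whether a bromine or a fluorine would read the same way if only its place on the aryl group changed. They also leave open how the number would respond to a different kind of group on that aryl ring, such as a dimethylamino group or a carboxylic acid.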